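The source may hold more compounds than are shown below. What is called first, only, known or untested is meant among the compounds shown, and "the series" means these compounds.

Compound 1 `COc1ncc(-c2ccc3nc(NC(=O)N(C)C)nn3c2)cc1NS(=O)(=O)c1ccc(F)cc1` opens the comparison. Within the data shown here, in a functional assay on MCF7 cells (Homo sapiens) for cytotoxicity, read by MTT assay, with a stated time of 72 h (a higher number here means a weaker inhibitor, a lower number a stronger inhibitor), compound 1 gives 1560 nM, the higher of the two numbers measured so far; compound 2 `CCN(CC)CCNC(=O)Nc1nc2ccc(-c3cnc(OC)c(NS(=O)(=O)c4ccc(F)cc4F)c3)cn2n1` gives 740 nM in this assay, a gap beyond the usual scatter. Compound 3 `CNC(=O)Nc1nc2ccc(-c3cnc(OC)c(NS(=O)(=O)c4ccc(F)cc4)c3)cn2n1` has not yet been measured. It differs from compound 1 by hydrogen in place of methyl on an amide-type nitrogen. Among the measured compounds shown here, no measured pair shows a change of this kind, so the step is expected to be small, a 1.2-fold lower number from compound 1 to compound 3 (0.08 log units; within the scatter), and not beyond the usual scatter in either direction. Compound 3 is therefore expected to give about 1300 nM in this assay, within a range of 500 nM to 3500 nM.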

Compound 3, half-maximal inhibitory concentration: 250 nM
Beside the measured number, compound 3's estimate is 5.2-fold (0.72 log units) above it; measured number below the stated range.
By their numbers in this assay, from the lowest: compound 3; then compound 2; then compound 1.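

Going from dimethylamino to methylamino removes just one carbon, yet in this assay it gives a 6.2-fold lower number from compound 1 to compound 3 (0.80 log units; beyond the scatter) and so lowers the number beyond the scatter. Among these compounds, this amide-type nitrogen is therefore a place where even the smallest change can matter, which the earlier compounds could not show. Nothing measured here gives a reason for the size of this step.

On these data alone, what an ethyl group or a longer chain would do in place of the methyl remains open. This single pair also cannot show whether the same step would hold with a different core.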